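A neutral sulfamide in place of a glycolamide

The source may report more compounds than this note shows. Statements on the series, on what has been measured and on what is new or still open speak of the compounds shown alone.

Three compounds share one core and differ only in the group carried on a saturated chain carbon bound to a saturated ring carbon. In an assay on isolated protein for displacement of a labelled ligand from 5-hydroxytryptamine receptor 6 (Homo sapiens) (on this read-out lower numbers stand for stronger inhibition and higher numbers for weaker inhibition), compound 1 `O=C1CN(C[C@@H]2CCCc3cc(S(=O)(=O)c4cccc(F)c4)ccc32)CCN1` gives 6.31 nM, compound 2 `CN(CC(N)=O)C[C@@H]1CCCc2cc(S(=O)(=O)c3cccc(F)c3)ccc21` gives 1.26 nM, and compound 3 `O=C(CO)NC[C@@H]1CCCc2cc(S(=O)(=O)c3cccc(F)c3)ccc21` gives 0.1 nM. Compound 3 stands lowest of the three: the step of a 63-fold lower number from compound 1 to compound 3 (1.80 log units; beyond the scatter) and the step of a 13-fold lower number from compound 2 to compound 3 (1.10 log units; beyond the scatter) both point toward it, and both exceed the usual scatter.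

Compound 4 `NS(=O)(=O)NC[C@@H]1CCCc2cc(S(=O)(=O)c3cccc(F)c3)ccc21` is the next variation: sulfamoyl in place of (hydroxymethyl)carbonyl on an amine nitrogen. The group that leaves and the group that enters both carry one hydrogen-bond donor and two hydrogen-bond acceptors and neither carries a net charge, so the change is smaller in kind than either step that led to compound 3, where a ring or a methylated amine gave way to an open amide. Within the data shown here, no measured pair bears on this exact exchange. The expectation is therefore a small step, a 3.0-fold higher number from compound 3 to compound 4 (0.48 log units; beyond the scatter), and compound 4 is estimated at 0.3 nM, between 0.05 nM and 2 nM in this assay.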

Compound 4, inhibition constant: 0.126 nM
Compound 4: middle estimate off by 2.4-fold (0.38 log units), on the high side, within the range that was stated.
By their numbers in this assay, from the lowest: compounds 3 and 4 (each within the scatter of the next); then compound 2; then compound 1.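

In this assay, exchanging (hydroxymethyl)carbonyl for sulfamoyl on the amine nitrogen gives a 1.3-fold higher number from compound 3 to compound 4 (0.10 log units; within the scatter), so the two groups cannot be told apart here and the carbonyl of compound 3 is not required for a low number at this position. The advantage over the other two groups also survives the exchange, with a 10-fold lower number from compound 2 to compound 4 (1.00 log units; beyond the scatter) and a 50-fold lower number from compound 1 to compound 4 (1.70 log units; beyond the scatter), so it does not belong to the (hydroxymethyl)carbonyl group alone. Nothing measured here explains why these two different groups read alike.

On these data alone, whether a plain acetyl or methanesulfonyl group on the same amine nitrogen would read alike remains open. So does the effect of a methyl group on that nitrogen, which would show whether its hydrogen matters.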